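This account rests on a few compounds, and the source may have more. Where it says the series, first, only, none or still open, it means among the compounds named here.

Measured compounds in a functional assay on L1210 cells (Mus musculus) for antiproliferative activity; on this read-out higher numbers stand for an effect only at larger amounts of compound and lower numbers for an effect already at smaller amounts:
compound 1 `CCCCCCCCCCCCO/N=C(\CCCCCC)c1cc(OC)c2c(c1OC)C(=O)C=CC2=O`: 0.193 ug/mL
compound 2 `CCCCCO/N=C/c1cc(OC)c2c(c1OC)C(=O)C=CC2=O`: 0.175 ug/mL
compound 3 `CCCCCCCCCCCCO/N=C/c1cc(OC)c2c(c1OC)C(=O)C=CC2=O`: 0.311 ug/mL

Compound 1 stands second highest of the three numbers in this assay, but its gap to compound 2 and its gap to compound 3 both lie within the scatter, so the three measured compounds cannot be separated on the numbers shown.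

Compound 4 `CCCCCC/C(=N\OCCCCC)c1cc(OC)c2c(c1OC)C(=O)C=CC2=O` arises from compound 1 by hydrogen in place of heptyl on a saturated chain carbon, five bonds along the chain from an oxygen on an unsaturated carbon. For the measured compounds named here, only one measured step bears on this change: a 1.8-fold higher number from compound 2 to compound 3 (0.25 log units; within the scatter), which is the same exchange run in the opposite direction, heptyl entering where compound 4 has hydrogen. That step stayed within the scatter, so the shortening of the chain in compound 4 is not expected to move this assay beyond the scatter either; if anything, a slightly lower number is expected, mirroring the small rise seen from compound 2 to compound 3.

Compound 4 is therefore estimated at 0.13 ug/mL, with a range of 0.06 ug/mL to 0.3 ug/mL, which means an expected step of a 1.5-fold lower number from compound 1 to compound 4 (0.17 log units; within the scatter) relative to compound 1.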

Compound 4, concentration for half-maximal effect: 0.224 ug/mL
Estimate against measurement, compound 4: 1.7-fold (0.24 log units) below, and the stated range covers the measured number.
By their numbers in this assay, from the lowest: compounds 2, 1, 4 and 3 (each within the scatter of the next).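

In this assay, hydrogen in place of heptyl on a saturated chain carbon, five bonds along the chain from an oxygen on an unsaturated carbon, gives a 1.2-fold higher number from compound 1 to compound 4 (0.06 log units; within the scatter). This change has now been read on the core of compound 1 as well as on that of compound 2, and it stays within the scatter on both. The two readings also agree within the scatter, so no dependence on the core can be read at this position: the same change on two cores in this assay, a 1.8-fold higher number (0.25 log units; within the scatter) from compound 2 to compound 3 and a 1.2-fold lower number (0.06 log units; within the scatter) from compound 4 to compound 1, 2.1-fold (0.31 log units) apart, within the scatter of two such steps

The compounds shown contain no step beyond the scatter, so they do not show which structural changes, if any, can shift this read-out. On these data alone, whether an amine, a carboxylic acid or a longer chain in place of heptyl at this position would move the number in this assay beyond the scatter stays open.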